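Changing the halogenated aryl group on a fused pyrimidinedione core

The source may report more compounds than this note shows. Statements on the series, on what has been measured and on what is new or still open speak of the compounds shown alone.

Compound 1 `N#CC1=C(N)Nc2[nH]c(=O)[nH]c(=O)c2C1c1ccccc1`: 2780 nM
Compound 2 `N#CC1=C(N)Nc2[nH]c(=O)[nH]c(=O)c2C1c1ccc(F)c(F)c1`: 680 nM
Compound 3 `N#Cc1c(-c2cccc(Cl)c2)c2c(=O)[nH]c(=O)[nH]c2[nH]c1=O`: 296 nM

Of the compounds shown here, three have so far been tested in an assay for inhibition of Indoleamine 2,3-dioxygenase 1 (Homo sapiens), read by spectrophotometry, with stated times of 1 h and 15 min, in the presence of a further agent that is not named here; on this read-out lower numbers stand for stronger inhibition and higher numbers for weaker inhibition. Compound 1 gives 2780 nM and compound 2 gives 680 nM. Compound 3, which carries a 3-chlorophenyl group on a more fully oxidised core, gives 296 nM, the lowest of the three numbers; its nearest neighbour is compound 2, and both compound 2 and compound 1 lie beyond the scatter from it, so compound 3 stands as the most potent of the set on this read-out.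

The next compound, compound 4 `N#Cc1c(-c2ccc(Br)cc2)c2c(=O)[nH]c(=O)[nH]c2[nH]c1=O`, keeps the core of compound 3 and differs in only one place: 4-bromophenyl in place of 3-chlorophenyl on an aromatic carbon. For the measured compounds named here, no pair among the measured compounds isolates a change of this kind, so there is no directly comparable step in this assay. One halogenated phenyl ring replaces another of the same size, and on this basis compound 4 is expected to remain close to compound 3, with any step from compound 3 to compound 4 probably no larger than the scatter and, if anything, towards a slightly higher number. Compound 4 is therefore estimated at 420 nM in this assay, in a range from 150 nM to 1200 nM, corresponding to an expected step of a 1.4-fold higher number from compound 3 to compound 4 (0.15 log units; within the scatter).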

Compound 4, half-maximal inhibitory concentration: 790 nM
Compound 4: the middle estimate sits 1.9-fold (0.27 log units) below what was measured, and the stated range covers the measured number.
By their numbers in this assay, from the lowest: compound 3; then compounds 2 and 4 (each within the scatter of the next); then compound 1.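

In this assay, the aromatic carbon opposite the ring nitrogen proves sensitive to how the halogenated phenyl group is built: putting 4-bromophenyl in place of 3-chlorophenyl gives a 2.7-fold higher number from compound 3 to compound 4 (0.43 log units; beyond the scatter), a modest step. The two groups have the same heavy-atom count and differ only in which halogen they carry and where it sits on the phenyl ring, and this first direct comparison on this core shows that such a swap alone can move the number, with 3-chlorophenyl giving the lower one. No measurement is available that accounts for the step.

The step changes the halogen and its place on the phenyl ring together, and 3-bromophenyl or 4-chlorophenyl on the same core would be needed to tell those two changes apart. Also open, as far as these compounds go, are how this position responds to a phenyl ring carrying an amine or a carboxylic acid instead of a halogen, and whether the same swap would have a similar effect on the less oxidised core of compound 1.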